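A few compounds are considered here, and "the series" means these few. Any claim that something is new, unique, unknown or untested is made for them only; others in the source may bear on it.

Compound 1 `COc1ccc([C@@H]2C/C(=N\N)c3c(O)cc(OC)cc3O2)cc1`: >= 11300 nM, a limit
Compound 2 `COc1ccc([C@@H]2C/C(=N\Nc3ccccc3)c3c(O)cc(OC)cc3O2)cc1`: >= 11300 nM, a limit
Compound 3 `COc1ccc([C@@H]2C/C(=N\NC(=O)c3ccc(N)cc3)c3c(O)cc(OC)cc3O2)cc1`: 3900 nM

All three were tested in a functional assay on L5178Y cells (Mus musculus) for inhibition, read by MTT assay, with a stated time of 24 h; a higher number here means a weaker inhibitor, a lower number a stronger inhibitor. Within the data shown here, compound 3 holds the only true number, while the other two rest at the limit of >= 11300 nM in this assay, at which 2 of the 3 values shown sit. Compound 4 `COc1ccc([C@@H]2C/C(=N\NC(=O)Cc3c[nH]c4ccccc34)c3c(O)cc(OC)cc3O2)cc1` changes compound 3 as follows: (1H-indol-3-yl)methyl in place of 4-aminophenyl on a carbonyl carbon. In short, (1H-indol-3-yl)methyl replaces 4-aminophenyl on a carbonyl carbon. The nearest measured steps are an at least 2.8-fold lower number from compound 1 to compound 3 (0.46 log units; beyond the scatter) and an at least 2.8-fold lower number from compound 2 to compound 3 (0.46 log units; beyond the scatter), each bringing in (4-aminophenyl)carbonyl on an amine nitrogen. Compound 4 keeps that carbonyl, but neither step varies the group on it, so no change beyond the scatter is expected in this assay. The expected step is a 1.0-fold higher number from compound 3 to compound 4 (0.01 log units; within the scatter). Compound 4 is estimated at 4000 nM, with an expected range of 1500 nM to 11000 nM.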

Compound 4, half-maximal inhibitory concentration: 8600 nM
The estimate for compound 4 lay 2.2-fold (0.33 log units) below the measured number; low and high end bracket the measured number.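

In this assay, the group on the carbonyl carbon makes a difference: (1H-indol-3-yl)methyl in place of 4-aminophenyl gives a 2.2-fold higher number from compound 3 to compound 4 (0.34 log units; beyond the scatter). Among these compounds, the earlier steps only brought in the carbonyl on the amine nitrogen; this is the first reading of what stands on that carbonyl. Compound 3 and compound 4 are the only two that carry true numbers, the others resting at a limit: the limit of >= 11300 nM in this assay, at which 2 of the 4 values shown sit.

The compounds shown do not tell whether the step belongs to the indolyl ring or to the methylene link within (1H-indol-3-yl)methyl. A benzyl group on that carbonyl carbon would separate the two.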